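The source may report more compounds than this note shows. Statements on the series, on what has been measured and on what is new or still open speak of the compounds shown alone.

In a functional assay on KB cells (Homo sapiens) for antiproliferative activity, read by MTT assay, with a stated time of 48 h (on this read-out lower numbers stand for stronger inhibition and higher numbers for weaker inhibition), compound 2 `CCOC(=O)N1CCC(N(Cc2ccc(O)cc2)C(=O)N(C)C)CC1` gives 48600 nM, the highest number among the three measured compounds. Compound 1 `CCOC(=O)N1CCC(N(Cc2cccc([N+](=O)[O-])c2)C(=O)N(C)C)CC1` gives 15600 nM, and compound 3 `CN(C)C(=O)N(Cc1ccc([N+](=O)[O-])cc1)Cc1ccco1` gives 17500 nM; each of these lies below compound 2 by more than the scatter. Compound 4 `CCOC(=O)N1CCC(N(Cc2cc(Br)ccc2O)C(=O)N(C)C)CC1` has not yet been measured. It differs from compound 2 by 5-bromo-2-hydroxyphenyl in place of 4-hydroxyphenyl on a saturated chain carbon bound to an amide-type nitrogen. Within the data shown here, only one measured step touches this position: a 3.1-fold higher number from compound 1 to compound 2 (0.49 log units; beyond the scatter). Among the measured compounds shown here, that step exchanged a nitrophenyl for a hydroxyphenyl and cost a modest amount of potency; the change to compound 4 instead replaces one hydroxyphenyl with another that also carries a bromine, and no measured pair covers such an exchange. On this thin basis the expected step in this assay is a 1.6-fold lower number from compound 2 to compound 4 (0.21 log units; within the scatter), a small movement that may well stay within the scatter. Compound 4 is therefore estimated at 30000 nM, with a range from 10000 nM to 90000 nM.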

Compound 4, half-maximal inhibitory concentration: 24600 nM
The estimate for compound 4 lay 1.2-fold (0.09 log units) above the measured number; measured number inside the range.
By their numbers in this assay, from the lowest: compounds 1, 3, 4 and 2 (each within the scatter of the next, the first and the last beyond it).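

In this assay, among these compounds, the exchange of 4-hydroxyphenyl for 5-bromo-2-hydroxyphenyl gives a 2.0-fold lower number from compound 2 to compound 4 (0.30 log units; within the scatter) and is the first hydroxyphenyl-for-hydroxyphenyl exchange measured on this saturated chain carbon; it does not move the number beyond the scatter. The exchange of 3-nitrophenyl for 5-bromo-2-hydroxyphenyl gives a 1.6-fold higher number from compound 1 to compound 4 (0.20 log units; within the scatter) and also stays within the scatter, whereas 4-hydroxyphenyl in place of 3-nitrophenyl gives a 3.1-fold higher number from compound 1 to compound 2 (0.49 log units; beyond the scatter) and goes beyond it, so the earlier step does not extend to every hydroxyphenyl at this place. No measurement here offers an explanation for these steps.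

Compound 4 adds the bromine and carries its hydroxyl at a different ring position, so the shown compounds do not separate these two changes. Going by these compounds, how a methoxyphenyl, an aminophenyl or a carboxyphenyl group would read at this place also remains open.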